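A few compounds are considered here, and "the series" means these few. Any claim that something is new, unique, unknown or untested is made for them only; others in the source may bear on it.

Measured compounds in an assay on isolated protein for inhibition of MAP kinase-interacting serine/threonine-protein kinase 1 (Homo sapiens), read by HTRF, in the presence of a further agent that is not named here; on this read-out higher numbers stand for weaker inhibition and lower numbers for stronger inhibition:
- compound 1 `O=C(c1cccc(C#Cc2ccccc2Nc2ncnc3ccc(Cl)nc23)c1)N1CCOCC1`: > 10000 nM
- compound 2 `COC(=O)c1oc2ccc(Nc3ncnc4ccc(Cl)nc34)cc2c1C`: > 10000 nM
- compound 3 `Cc1c(C(=O)N(C)C)oc2ccc(Nc3ncnc4ccc(Cl)nc34)cc12`: > 10000 nM

Each of these three values is a limit of the assay and not a number. Compound 3 therefore has no measured value of its own in this assay, only the limit. The same limit holds for the other two, since all three sit at the limit of > 10000 nM in this assay, at which 3 of the 3 values shown sit. Among the compounds with values here, the one step among measured compounds that differs in a single place, a step that the two limits leave unreadable from compound 2 to compound 3, runs from one limit to another and its size cannot be read.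

Compound 4 `CNC(=O)c1oc2ccc(Nc3ncnc4ccc(Cl)nc34)cc2c1C` differs from compound 3 by hydrogen in place of methyl on an amide-type nitrogen. Within the data shown here, no measured step bears directly on this change, and the only neighbouring step, dimethylamino in place of methoxy on a carbonyl carbon, is itself unreadable. With three limits and no readable step, there is no ground for expecting compound 4 to move out of the range of the limit. Compound 4 is therefore estimated at 15000 nM, with a range from 4000 nM to 60000 nM. The expected step that the limit leaves unreadable from compound 3 to compound 4 is thus no change beyond the scatter, with a high chance that this assay again reports only a limit.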

Compound 4, half-maximal inhibitory concentration: > 10000 nM
Compound 4 ended at the assay's limit (the forecaster's own chance of this, stated with the estimate: 85%); the middle value does not contradict the limit.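

In this assay compound 4 gives > 10000 nM as a limit of the assay and not a number. Within the data shown here, no step to compound 4 from compound 2 or compound 3 can be read. The compounds shown leave open whether any change on the shared core gives a readable value, all resting on one limit: the limit of > 10000 nM in this assay, at which 4 of the 4 values shown sit.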